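Methyl Placement on the Anilino Group

The source may hold more compounds than are shown below. What is called first, only, known or untested is meant among the compounds shown, and "the series" means these compounds.

Compound 2 `O=C(O)COc1ccc(NC(=O)C(=O)Nc2ccccc2)cc1F` gives 26.5% in a functional assay on CHO cells for agonist activity at Free fatty acid receptor 1 (Homo sapiens), read by FLIPR, tested at 300 nM; on this read-out higher numbers stand for a stronger effect at the one concentration tested and lower numbers for a weaker effect. Of the three measured compounds it carries the lowest number: compound 3 `Cc1ccc(NC(=O)C(=O)Nc2ccc(OCC(=O)O)c(F)c2)cc1` gives 29.9%, a gap that lies within the scatter, while compound 1 `Cc1cc(OCCCS(C)(=O)=O)cc(C)c1-c1cccc(COc2ccc(OCC(=O)O)c(F)c2)c1` gives 67.3%, a gap beyond it. Compound 4 `Cc1cccc(NC(=O)C(=O)Nc2ccc(OCC(=O)O)c(F)c2)c1` has not yet been measured; compared with compound 2 it shows (methyl in place of hydrogen on an aromatic carbon). For the measured compounds named here, the one step that bears on this, a number 3.4 percentage points higher from compound 2 to compound 3 (within the scatter), placed a methyl on the same ring and moved the number by less than the scatter. A similar outcome is therefore expected here, with a number 2.5 percentage points higher from compound 2 to compound 4 (within the scatter) amounting to no step beyond the scatter. Compound 4 is estimated at 29%, within a range from 17% to 42%.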

Compound 4, a percentage reported as activity, at one concentration (the size of the read-out at that concentration, not a potency): 36.3%
Compound 4: middle estimate off by 7.3 percentage points, on the low side; the range from low to high includes it.
By their numbers in this assay, from the lowest: compounds 2, 3 and 4 (each within the scatter of the next); then compound 1.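

Placing a methyl on the phenyl ring to give the 3-methylphenyl group produces a number 9.8 percentage points higher from compound 2 to compound 4 (within the scatter), so this position, like the one in compound 3, shows no step beyond the scatter in this assay. Moving the methyl from 4-methylphenyl to 3-methylphenyl produces a number 6.4 percentage points higher from compound 3 to compound 4 (within the scatter), so these two placements cannot be told apart on this read-out. Nothing available explains these small differences. On these data alone, it remains open whether a chlorine atom, a methoxy group or a longer chain at this same place would move the number beyond the scatter.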